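This account rests on a few compounds, and the source may have more. Where it says the series, first, only, none or still open, it means among the compounds named here.

Measured compounds: compound 1 `CCOc1cc(NC(=O)C2(NC(=O)c3ccc4c(C5CCCC5)c(-c5ncc(Cl)cn5)n(C)c4c3)CCC2)ccc1/C=C/C(=O)OC(=O)C[C@H](O)C(=O)O` and compound 2 `CCOc1cc(NC(=O)C2(NC(=O)c3ccc4c(C5CCCC5)c(-c5ncc(Cl)cn5)n(C)c4c3)CCC2)ccc1/C=C/C(=O)OCOP(=O)(O)OC(C)(C)C`, plus compound 3 `CCOc1cc(NC(=O)C2(NC(=O)c3ccc4c(C5CCCC5)c(-c5ncc(Cl)cn5)n(C)c4c3)CCC2)ccc1/C=C/C(=O)OCc1ccccc1`.

In an ADME assay (liver) for pharmacokinetics, with Liver microsome (Homo sapiens) as the target, using microsomes (on this read-out lower numbers stand for a shorter-lived compound and higher numbers for a longer-lived compound), compound 1 gives 5.57 h and compound 2 gives 1.48 h. For compound 3 the assay reports only a limit, > 5 h, so its place among the measured numbers is not fixed. Compound 4 `CCOc1cc(NC(=O)C2(NC(=O)c3ccc4c(C5CCCC5)c(-c5ncc(Cl)cn5)n(C)c4c3)CCC2)ccc1/C=C/C(=O)OCC(=O)N1CCCC1` differs from compound 3 in one place: (pyrrolidin-1-yl)carbonyl in place of phenyl on a saturated chain carbon bound to an oxygen next to a carbonyl group. For the measured compounds named here, of the measured steps, the one ending at compound 3 bears on this change: an at least 3.3-fold higher number from compound 2 to compound 3 (0.52 log units; beyond the scatter), where a ring-free group on a saturated chain carbon bound to an oxygen next to a carbonyl group belonged to the shorter-lived compound. The step that the limit leaves unreadable from compound 1 to compound 3 adds nothing readable. With a ring-free group entering again at that position, a shorter half-life is expected, an at least 1.6-fold lower number from compound 3 to compound 4 (0.22 log units; that floor lies within the scatter). The estimate for compound 4 is 3 h, in the range 1.2 h to 6 h.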

Compound 4, half-life: 1.65 h
Compound 4: middle estimate off by 1.8-fold (0.26 log units), on the high side; low and high end bracket the measured number.
By their numbers in this assay, from the lowest: compounds 2 and 4 (each within the scatter of the next); then compound 1.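

In this assay compound 3 carries only a limit: the limit of > 5 h in this assay, at which 1 of the 4 values shown sits.
Even so, an at least 3.0-fold lower number from compound 3 to compound 4 (0.48 log units; beyond the scatter) shows that the half-life falls although the group that enters, (pyrrolidin-1-yl)carbonyl, still holds a ring. The other steps are a 1.1-fold higher number from compound 2 to compound 4 (0.05 log units; within the scatter) and a 3.4-fold lower number from compound 1 to compound 4 (0.53 log units; beyond the scatter), so a ring at this position does not by itself go with a longer half-life, and ring-free compound 1 goes against any such rule.

Going by these compounds, it stays open whether the carbonyl or the pyrrolidine ring matters more here. A dimethylamide or a plain carboxylic acid at this position could help to separate the two.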